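The source may report more compounds than this note shows. Statements on the series, on what has been measured and on what is new or still open speak of the compounds shown alone.

In a functional assay on MCF7 cells (Homo sapiens) for cytotoxicity, read by MTT assay, with a stated time of 24 h (on this read-out lower numbers stand for stronger inhibition and higher numbers for weaker inhibition), compound 1 `C/C(=N\NC(=O)/C(C#N)=C/c1ccccc1)c1c(O)c2ccc(O)cc2oc1=O` gives 19200 nM. Compound 2 `C/C(=N\NC(=O)/C(C#N)=C/c1cccc([N+](=O)[O-])c1)c1c(O)c2ccc(O)cc2oc1=O`, which carries a nitro in place of hydrogen on an aromatic carbon, gives 16400 nM. Among the measured compounds shown here, these two values lie within the scatter of each other, so compound 2 cannot be ranked against the only other measured compound. Compound 3 `C/C(=N\NC(=O)/C(C#N)=C/c1ccc([N+](=O)[O-])cc1)c1c(O)c2ccc(O)cc2oc1=O` has yet to be measured in this assay. It has the same atoms as compound 2, joined differently: 4-nitrophenyl in place of 3-nitrophenyl on a double-bonded chain carbon bound to a double-bonded chain carbon. In words, 4-nitrophenyl stands in place of 3-nitrophenyl on a double-bonded chain carbon bound to a double-bonded chain carbon. For the measured compounds named here, the one measured step that bears on this change is the introduction of the nitro, a 1.2-fold lower number from compound 1 to compound 2 (0.07 log units; within the scatter), and it stays within the scatter. Going by the values given here, no measured pair compares two nitro positions directly, so this evidence is indirect, and no step beyond the scatter is expected in this assay. The estimate amounts to a 1.0-fold lower number from compound 2 to compound 3 (0.01 log units; within the scatter), with no direction expected beyond the scatter. For compound 3 the expected value is 16000 nM, with an estimated range from 7500 nM to 34000 nM.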

Compound 3, half-maximal inhibitory concentration: 8200 nM
For compound 3 the middle estimate is 2.0-fold (0.29 log units) above the measured one; the range from low to high includes it.
By their numbers in this assay, from the lowest: compounds 3, 2 and 1 (each within the scatter of the next, the first and the last beyond it).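

Moving the nitro from 3-nitrophenyl to 4-nitrophenyl gives a 2.0-fold lower number from compound 2 to compound 3 (0.30 log units; within the scatter), so in this assay compound 2 and compound 3 still cannot be ranked against each other. Among the compounds shown here, the new information lies in the comparison with the unsubstituted phenyl: a 2.3-fold lower number from compound 1 to compound 3 (0.37 log units; beyond the scatter) is a modest step, but it is the first to pass beyond the scatter, whereas the earlier step, a 1.2-fold lower number from compound 1 to compound 2 (0.07 log units; within the scatter), did not. Thus, a nitro on this ring can separate a compound from compound 1 when it is present as 4-nitrophenyl, although the data do not establish a real difference between the two nitrophenyl groups, and nothing available accounts for this result.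

The compounds shown leave open whether this step is specific to the nitro or would also appear with an amine, a carboxylic acid or a methoxy group in its place on 4-nitrophenyl. They also leave open whether any change on this ring can produce a step larger than this modest one in these cells.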